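A few compounds are considered here, and "the series" means these few. Any claim that something is new, unique, unknown or untested is made for them only; others in the source may bear on it.

Measured so far:
compound 1, `C(=N/Nc1nc(-c2ccccc2)cs1)\c1ccc(N2CCCC2)cc1`; in an assay on isolated protein for inhibition of Amine oxidase [flavin-containing] B (Homo sapiens), read by fluorescence and Amplex Red, with a stated time of 30 min (on this read-out lower numbers stand for stronger inhibition and higher numbers for weaker inhibition), compound 1 gives > 1000000 nM, a limit of the assay.
compound 2, `Clc1ccc(-c2csc(N/N=C/c3ccc(N4CCCC4)cc3)n2)cc1`; in this assay compound 2 gives 761000 nM.

Compound 2 holds the only number shown in this assay; the other entry is a limit, (the limit of > 1000000 nM in this assay, at which 1 of the 2 values shown sits). Compound 3, `Clc1ccc(-c2csc(N/N=C/c3ccc(N4CCCC4)cc3)n2)c(Cl)c1`, differs from compound 2 by chloro in place of hydrogen on an aromatic carbon. Among the compounds with values here, the one measured step, an at least 1.3-fold lower number from compound 1 to compound 2 (0.11 log units; that floor lies within the scatter), is the same kind of change and stays within scatter. A step of similar size is therefore expected for compound 3, that is a 1.3-fold lower number from compound 2 to compound 3 (0.10 log units; within the scatter), with nothing beyond scatter. For compound 3 the expected value in this assay is 600000 nM, ranging from 250000 nM to 1500000 nM.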

Compound 3, half-maximal inhibitory concentration: 131000 nM
Compound 3: middle estimate off by 4.6-fold (0.66 log units), on the high side, outside the stated range (below it).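

Chloro on this aromatic carbon, ortho to a large group and meta to a chloro group, gives a 5.8-fold lower number from compound 2 to compound 3 (0.76 log units; beyond the scatter) in this assay, the first step in the series that reads beyond the scatter. Overall, 2,4-dichlorophenyl in place of phenyl gives an at least 7.6-fold lower number from compound 1 to compound 3 (0.88 log units; beyond the scatter). That size is only a floor, since compound 1 stands at a limit: the limit of > 1000000 nM in this assay, at which 1 of the 3 values shown sits.

Open, on these data alone, is whether this effect is specific to chloro at this position, or whether a methoxy group or an amine on the same carbon would match it. Also open, as far as these compounds go, is whether the step depends on the chloro group already present.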